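The compounds below may be only part of what the source reports. "The series", "measured", "known", "first", "only" and "open" are said of these compounds alone.

Working notes on the series, a functional assay on SW480 cells (Homo sapiens) for cytotoxicity, read by MTT assay, with a stated time of 24 h; on this read-out higher numbers stand for weaker inhibition and lower numbers for stronger inhibition.

Compound 3, `C=CC1=C(C(=O)NCc2ccc(Cl)cc2)C(c2ccc(OC)cc2)OC1`, is the point of reference. In this assay compound 3 gives only a limit, > 100000 nM, not a number. Compound 1, `C=CC1=C(C(=O)NCc2ccc(Cl)cc2)C(c2ccc(F)cc2)OC1`, differs from compound 3 by the substituent on the aromatic ring carried by the shared core. In this assay compound 1 also gives only a limit, > 100000 nM. Compound 2, `C=CC1=C(C(=O)NC2CCCCC2)C(c2ccc(OC)cc2)OC1`, carries a cyclohexyl on the amide-type nitrogen instead of the 4-chlorobenzyl of compound 3. In this assay compound 2 likewise gives only a limit, > 100000 nM. Both steps into compound 3 are therefore unreadable: a step that the two limits leave unreadable from compound 1 to compound 3 and a step that the two limits leave unreadable from compound 2 to compound 3. The whole picture is the limit of > 100000 nM in this assay, at which 3 of the 3 values shown sit.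

Compound 4, `C=CC1=C(C(=O)Nc2ccc(C)cc2)C(c2ccc(OC)cc2)OC1`, is the next change: 4-methylphenyl in place of 4-chlorobenzyl on an amide-type nitrogen. Within the data shown here, the one measured step touching the amide-type nitrogen, a step that the two limits leave unreadable from compound 2 to compound 3, runs between two limits and cannot say whether exchanging the group on that nitrogen moves the number at all. With every measured value sitting at the limit, no direction can be read, and the most likely outcome for compound 4 is a further limit in this assay.

Compound 4 is accordingly expected at about 150000 nM in this assay, with a range from 40000 nM to 600000 nM. The step from compound 3 to compound 4 that this estimate implies, a step that the limit leaves unreadable from compound 3 to compound 4, is expected to be no more than scatter, and most probably it will not be readable at all.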

Compound 4, half-maximal inhibitory concentration: > 100000 nM
Compound 4: a limit, no number; the forecaster's own chance of this, stated with the estimate: 85%; the middle value is on the limit's open side.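

In this assay compound 4 gives only a limit, > 100000 nM, so no new step can be read from compound 4 to either compound 3 or compound 2. The compounds shown leave open whether any change on the shared core moves the value at all, because everything stands at one limit: the limit of > 100000 nM in this assay, at which 4 of the 4 values shown sit.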